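From 4-bromophenyl to 3-chlorophenyl

A few compounds are considered here, and "the series" means these few. Any claim that something is new, unique, unknown or untested is made for them only; others in the source may bear on it.

In a functional assay on EC9706 cells (Homo sapiens) for cytotoxicity, read by MTT assay, with a stated time of 72 h (a higher number here means a weaker inhibitor, a lower number a stronger inhibitor), compound 1 `CC(=O)c1ccc(NC(=O)CSC(=S)N[C@H]2CCOC2=O)cc1` reaches only a limit, > 128000 nM. Compound 2 `O=C(CCl)Nc1ccc(C(=O)/C=C/c2cccc(Cl)c2)cc1` gives 5560 nM, and compound 3 `O=C(CSC(=S)N[C@H]1CCOC1=O)Nc1ccc(C(=O)/C=C/c2ccc(Br)cc2)cc1` gives 91200 nM, the higher of these two numbers. Compound 4 `O=C(CSC(=S)N[C@H]1CCOC1=O)Nc1ccc(C(=O)/C=C/c2cccc(Cl)c2)cc1` differs from compound 3 in one place: 3-chlorophenyl in place of 4-bromophenyl on a double-bonded chain carbon bound to a double-bonded chain carbon. It carries 3-chlorophenyl in place of 4-bromophenyl on a double-bonded chain carbon bound to a double-bonded chain carbon. Among the measured compounds shown here, the one measured step that bears on this is an at least 1.4-fold lower number from compound 1 to compound 3 (0.14 log units; that floor lies within the scatter), which installed the 4-bromophenyl group, and no measured step exchanges this group directly. No shift beyond the scatter is therefore expected, and the estimated change is a 1.3-fold lower number from compound 3 to compound 4 (0.11 log units; within the scatter). For compound 4 the expected value is 70000 nM, with an estimated range of 25000 nM to 128000 nM.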

Compound 4, half-maximal inhibitory concentration: 32500 nM
Beside the measured number, compound 4's estimate is 2.2-fold (0.33 log units) above it, and the stated range covers the measured number.
By their numbers in this assay, from the lowest: compound 2; then compound 4; then compound 3. At a limit, above all of these: compound 1.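

In this assay the exchange on a double-bonded chain carbon bound to a double-bonded chain carbon gives a 2.8-fold lower number from compound 3 to compound 4 (0.45 log units; beyond the scatter) and shows that this position responds to the choice of halogen-bearing phenyl group. Against the methyl of compound 1, 2-(3-chlorophenyl)ethenyl gives an at least 3.9-fold lower number from compound 1 to compound 4 (0.59 log units; beyond the scatter) and now clears the scatter, though only as a floor set by a limit: the limit of > 128000 nM in this assay, at which 1 of the 4 values shown sits. Chlorine on the saturated chain carbon bound to a carbonyl carbon still leads, with a 5.8-fold higher number from compound 2 to compound 4 (0.77 log units; beyond the scatter) for the larger group in its place.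

The halogen and its ring position change together here, so 3-bromophenyl or 4-chlorophenyl would be needed to separate them. On these data alone, how an amine on this phenyl ring would read remains open.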